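Dropping one chloro group: what to expect for compound 4

The source may report more compounds than this note shows. Statements on the series, on what has been measured and on what is new or still open speak of the compounds shown alone.

Of the compounds shown here, three have been tested in a functional assay on NCI-H226 cells (Homo sapiens) for cytotoxicity, read by sulforhodamine B assay, with a stated time of 48 h; on this read-out lower numbers stand for higher toxicity in this test and higher numbers for lower toxicity in this test. Compound 1 `ClCc1cccc(Cn2cnc3ncnc(Cl)c32)c1` gives 9330 nM. Compound 2 `ClCc1ccc(Cn2cnc3nc(Cl)nc(Cl)c32)cc1` gives 15500 nM, and compound 3 `ClCc1cccc(Cn2cnc3nc(Cl)nc(Cl)c32)c1` gives 20000 nM. Compound 2 and compound 3 are built from the same atoms joined differently; the difference between their two cores is not broken down here. Between compound 2 and either of the other two, the gap is within the usual scatter, so no order among them can be claimed from these numbers alone.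

Compound 1 and compound 3 differ in one place: hydrogen in place of chloro on an aromatic carbon. This change gave a 2.1-fold lower number from compound 3 to compound 1 (0.33 log units; beyond the scatter), a step that lies beyond the scatter.

Compound 4 `ClCc1ccc(Cn2cnc3ncnc(Cl)c32)cc1` has not yet been tested. It relates to compound 2 exactly as compound 1 relates to compound 3: hydrogen in place of chloro on an aromatic carbon. The surroundings of the change are the same in both pairs, so this is the same change. Going by the values given here, the only guide available is the one measured example, and a second pair cannot show whether the step repeats on a different core. Because the earlier pair gave a 2.1-fold lower number from compound 3 to compound 1 (0.33 log units; beyond the scatter), the step from compound 2 to compound 4 is expected to be of similar size, about a 2.1-fold lower number from compound 2 to compound 4 (0.32 log units; beyond the scatter). Among the compounds with values here, compound 4 is therefore estimated to give 7500 nM, with a likely range from 3000 nM to 18000 nM given that only one prior example supports this expectation.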

Compound 4, concentration lethal to 50% of the cells: 37200 nM
For compound 4 the middle estimate is 5.0-fold (0.70 log units) below the measured one, outside the stated range (above it).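

In this assay, putting hydrogen in place of the chloro group between two ring nitrogen atoms gave a 2.4-fold higher number from compound 2 to compound 4 (0.38 log units; beyond the scatter), so on this core the change goes with lower toxicity in this test. Set beside the earlier pair, the same change moved the number in opposite directions on the two cores: the same change on two cores in this assay, a 2.1-fold lower number (0.33 log units; beyond the scatter) from compound 3 to compound 1 and a 2.4-fold higher number (0.38 log units; beyond the scatter) from compound 2 to compound 4, 5.1-fold (0.71 log units) apart, beyond the scatter of two such steps This shows that in this series the effect of the swap cannot simply be carried from one core to the other as a fixed step, even when the immediate surroundings of the change look the same; it does not show why the two cores part ways, and with only two pairs it cannot tell which direction a further core would take.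

Still open, going by these compounds, is what other groups would do on that same ring carbon, such as an amine or a longer carbon chain in place of the chloro group, and whether their effects would also differ between the two cores. All four compounds also carry a chloromethyl group, which leaves open how a compound with a plain methyl group or a carboxylic acid at that place would behave in this test.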